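Dimethylphenyl Replaced by Nitrophenyl on a Shared Core

The compounds below may be only part of what the source reports. "The series", "measured", "known", "first", "only" and "open" are said of these compounds alone.

Of the compounds shown here, three on one shared core have been measured in an assay for binding affinity to dual specificity mitogen-activated protein kinase kinase 4 (Homo sapiens), read by KINOMEscan, tested at 100 nM; a lower number here means a stronger effect, a higher number a weaker effect of the compound at the concentration tested. Compound 1 `CCCS(=O)(=O)Nc1ccc(F)c(C(=O)c2n[nH]c3ncc(-c4ccccc4)cc23)c1F` gives 2.4%, and compound 2 `CCCS(=O)(=O)Nc1ccc(F)c(C(=O)c2n[nH]c3ncc(-c4ccccc4F)cc23)c1F` gives 2%; the step of a number 0.4 percentage points lower from compound 1 to compound 2 (within the scatter) lies within the scatter. Compound 3 `CCCS(=O)(=O)Nc1ccc(F)c(C(=O)c2n[nH]c3ncc(-c4ccc(C)c(C)c4)cc23)c1F` gives 20%, the highest of the three numbers, reached through a number 17.6 percentage points higher from compound 1 to compound 3 (beyond the scatter) and a number 18 percentage points higher from compound 2 to compound 3 (beyond the scatter). Compound 4 `CCCS(=O)(=O)Nc1ccc(F)c(C(=O)c2n[nH]c3ncc(-c4cccc([N+](=O)[O-])c4)cc23)c1F` carries the change (3-nitrophenyl in place of 3,4-dimethylphenyl on an aromatic carbon). Both measured steps ending at compound 3 bear on it: each exchanged the aryl group at this place for 3,4-dimethylphenyl and raised the number modestly. Among the compounds with values here, no measured step involves a nitro group, so the size of any return is uncertain. The step of a number 12 percentage points lower from compound 3 to compound 4 (beyond the scatter) is therefore expected to be modest and downward. Compound 4 is estimated at 8%, between 1% and 35%.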

Compound 4, a percentage reported as activity, at one concentration (the size of the read-out at that concentration, not a potency): 15%
Estimate against measurement, compound 4: 7 percentage points below, within the range that was stated.
By their numbers in this assay, from the lowest: compounds 2 and 1 (each within the scatter of the next); then compounds 4 and 3 (each within the scatter of the next).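

In this assay the 3-nitrophenyl group stays above the unsubstituted phenyl level: nitro in place of hydrogen gives a number 12.6 percentage points higher from compound 1 to compound 4 (beyond the scatter) and 3-nitrophenyl in place of 2-fluorophenyl gives a number 13 percentage points higher from compound 2 to compound 4 (beyond the scatter). Exchanging 3,4-dimethylphenyl for 3-nitrophenyl gives a number 5 percentage points lower from compound 3 to compound 4 (within the scatter), so these two substituted rings cannot be told apart at this position. Nothing measured accounts for this result. Still open, as far as these compounds go, is whether an amine or a carboxylic acid on this phenyl ring would return the number to the level of compound 1 and compound 2. Also open, from the compounds shown here alone, is whether a nitro group at another carbon of that ring would read the same.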